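The source may hold more compounds than are shown below. What is called first, only, known or untested is meant among the compounds shown, and "the series" means these compounds.

Compound 3 `COc1ccccc1C(=O)Nc1ccc2nc(SCC(=O)NCc3ccc(Cl)cc3)sc2c1` gives 1100 nM in a functional assay on MCF7 cells (Homo sapiens) for cytotoxicity, read by MTT assay, with a stated time of 48 h (a higher number here means a weaker inhibitor, a lower number a stronger inhibitor), the lowest of the three numbers measured here. Its nearest neighbour is compound 2 `COc1ccc(CNC(=O)CSc2nc3ccc(NC(=O)CCl)cc3s2)cc1`, which in this assay gives 5100 nM; the furthest is compound 1 `CNC(=O)CSc1nc2ccc(NC(=O)c3ccccc3OC)cc2s1`, which gives 23400 nM. For the measured compounds named here, only one pair of measured compounds differs in a single place: adding a 4-chlorophenyl to the saturated chain carbon bound to the amide-type nitrogen gave a 21-fold lower number from compound 1 to compound 3 (1.33 log units; beyond the scatter), so what hangs on that chain carbon clearly matters.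

Compound 4 `COc1ccc(CNC(=O)CSc2nc3ccc(NC(=O)c4ccccc4OC)cc3s2)cc1` keeps everything else of compound 3 and changes one thing: methoxy in place of chloro on an aromatic carbon. Going by the values given here, no measured pair compares chloro with methoxy on that ring, and compound 2 carries the methoxy group but differs from compound 3 in a second place as well, so its value alone cannot settle the question. Among the compounds with values here, the step from compound 1 to compound 3 shows only that the ring itself helps, not which substituent on it is better. The expectation is therefore a modest change, a 1.6-fold higher number from compound 3 to compound 4 (0.21 log units; within the scatter), with a mild lean toward a higher number. Compound 4 is estimated to give 1800 nM in this assay, between 700 nM and 4500 nM.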

Compound 4, half-maximal inhibitory concentration: 9300 nM
Beside the measured number, compound 4's estimate is 5.2-fold (0.71 log units) below it, and the stated range ends below it.
By their numbers in this assay, from the lowest: compound 3; then compounds 2 and 4 (each within the scatter of the next); then compound 1.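

The group on this ring carbon is not interchangeable in this assay: methoxy in place of chloro gives an 8.5-fold higher number from compound 3 to compound 4 (0.93 log units; beyond the scatter), a step beyond the usual scatter, so 4-chlorobenzyl and 4-methoxybenzyl cannot be treated as equivalents on this scaffold. The earlier gain from adding the ring also proves to depend on its substituent, since the 4-methoxyphenyl ring gives only a 2.5-fold lower number from compound 1 to compound 4 (0.40 log units; beyond the scatter), whereas the 4-chlorophenyl ring gave a 21-fold lower number from compound 1 to compound 3 (1.33 log units; beyond the scatter), so the ring alone does not account for the larger gain. At the other end of the molecule, 2-methoxyphenyl in place of chloromethyl on a carbonyl carbon gives a 1.8-fold higher number from compound 2 to compound 4 (0.26 log units; within the scatter), a step within the scatter, so these two groups are not separated when the 4-methoxybenzyl group is present.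

Nothing measured here explains why chloro and methoxy differ on this ring. From the compounds shown here alone, it remains open how fluoro, bromo, methyl, an amine or a carboxylic acid would behave on the same ring carbon, and whether chloromethyl and 2-methoxyphenyl would remain inseparable with the 4-chlorobenzyl group in place.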